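Extending a methylsulfanyl arm with an ethoxycarbonyl group

The source may hold more compounds than are shown below. What is called first, only, known or untested is meant among the compounds shown, and "the series" means these compounds.

Two compounds from one study share a common core and were both tested in a functional assay on MCF7 cells (Homo sapiens) for cytotoxicity, read by MTT assay, with a stated time of 48 h; on this read-out higher numbers stand for weaker inhibition and lower numbers for stronger inhibition. Compound 1, `COc1cc(-c2nnc(SCc3ccccc3)n2/N=C/c2ccccc2)cc(OC)c1OC`, gives in this assay a reading of > 200000 nM, which is a limit of the assay rather than a number. Compound 2, `COc1ccc(/C=N/n2c(SC)nnc2-c2cc(OC)c(OC)c(OC)c2)c(OC)c1`, gives in this assay a reading of > 200000 nM, again a limit and not a number. Among the compounds with values here, compound 2 therefore stands at the limit, and the only other value shown sits at that same limit, as the limit of > 200000 nM in this assay, at which 2 of the 2 values shown sit, records. Compound 3, `CCOC(=O)CSc1nnc(-c2cc(OC)c(OC)c(OC)c2)n1/N=C/c1ccc(OC)cc1OC`, differs from compound 2 in one place: ethoxycarbonyl in place of hydrogen on a saturated chain carbon bound to a sulfur. No measured step joins any two of these compounds, so the size of this change cannot be read from a neighbouring pair. With both known readings resting at the limit, no shift beyond the scatter is expected, and the step that the limit leaves unreadable from compound 2 to compound 3 is expected to be small or absent. Compound 3 is accordingly estimated at 250000 nM, within a range from 80000 nM to 800000 nM, and is most likely to be reported once more only as a limit.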

Compound 3, half-maximal inhibitory concentration: > 200000 nM
Compound 3 ended at the assay's limit; the forecaster's own chance of this, stated with the estimate: 70%; the middle value lies beyond the limit too.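

Within the data shown here, compound 2 and compound 3 both rest at the limit of the assay, so no step between them can be read: the limit of > 200000 nM in this assay, at which 3 of the 3 values shown sit.

The compounds shown leave open whether the ethoxycarbonyl group changes the reading at all in this assay and whether any compound with this shared core gives a true number there.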